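Swapping the Ring on the Side Chain

This account rests on a few compounds, and the source may have more. Where it says the series, first, only, none or still open, it means among the compounds named here.

Of the compounds shown here, three have been measured in a functional assay on HL-60 cells (Homo sapiens) for cytotoxicity, read by WST assay, with a stated time of 48 h; on this read-out higher numbers stand for weaker inhibition and lower numbers for stronger inhibition. Compound 1 `COc1ccc(/C=C/C[C@H]2C[C@H]([C@H](O)c3ccc(OC)c(OC)c3)CO[C@@H]2c2ccc(OC)c(OC)c2)cc1OC` gives 23500 nM, and compound 3 `COc1ccc(/C=C/C[C@H]2C[C@@H]([C@@H](O)c3ccc(OC)c(OC)c3)CO[C@@H]2c2ccc(OC)c(OC)c2)cc1OC` gives 34700 nM. These two share every atom and bond, and their step, a 1.5-fold higher number from compound 1 to compound 3 (0.17 log units; within the scatter), rests on (the fact that compounds 1 and 3 differ only in the configuration as drawn). Compound 2 `COc1cccc(/C=C/C[C@H]2C[C@@H]([C@@H](O)c3ccccc3)CO[C@@H]2c2ccccc2)c1` gives 9620 nM in this assay, the lowest of the three numbers and therefore the strongest inhibitor among them, the other two lying beyond the usual scatter above it.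

Compound 4 `O[C@@H](c1ccccc1)[C@H]1CO[C@H](c2ccccc2)[C@@H](C/C=C/c2ccccc2F)C1` differs from compound 2 in one place: 2-fluorophenyl in place of 3-methoxyphenyl on a double-bonded chain carbon bound to a double-bonded chain carbon. Within the data shown here, no measured step changes the group on the double-bonded chain carbon; the only step available, the change of configuration from compound 1 to compound 3, concerns another part of the molecule and stayed within the scatter. There is thus no measured basis for a shift in either direction, and a step within the scatter is expected, with the uncertainty kept wide. For compound 4 the estimate means a step of a 1.0-fold higher number from compound 2 to compound 4 (0.02 log units; within the scatter). Compound 4 is expected to give 10000 nM, with a range from 3000 nM to 35000 nM.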

Compound 4, half-maximal inhibitory concentration: 9530 nM
For compound 4 the middle estimate is 1.0-fold (0.02 log units) above the measured one; the measured number falls inside the stated range.
By their numbers in this assay, from the lowest: compounds 4 and 2 (each within the scatter of the next); then compounds 1 and 3 (each within the scatter of the next).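

Among these compounds, the step of a 1.0-fold lower number from compound 2 to compound 4 (0.00 log units; within the scatter) is the first measured change at this position, on a double-bonded chain carbon bound to a double-bonded chain carbon, and it shows that in this assay 2-fluorophenyl and 3-methoxyphenyl cannot be told apart. The swap is not a small one on paper: the group that leaves has 8 heavy atoms, including an oxygen, and counts 1 hydrogen-bond acceptor, while the group that enters has 7 heavy atoms, including a fluorine, and counts 0, yet the two numbers stay within the usual scatter of repeat measurements. No measured fact here explains why these two compounds read alike.

The swap replaces the group and moves the substituent on the ring in a single step, so the compounds shown cannot separate those two parts of the change. On these data alone, it also remains open how the number would respond to a phenyl ring carrying an amine or a carboxylic acid at this position, or to a longer chain linking that ring to the shared core.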